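Working notes: from compound 3 to compound 4

The compounds below may be only part of what the source reports. "The series", "measured", "known", "first", "only" and "open" are said of these compounds alone.

The shared core is carried by compound 1 `CC(C)(C)c1nc(-c2ccccc2)ncc1-c1ccccc1`, compound 2 `CC(=O)N(C(C)=O)c1ncc(-c2ccccc2)c(C(C)(C)C)n1`, compound 3 `CCOC(=O)Nc1ncc(-c2ccccc2)c(C(C)(C)C)n1` and the unmeasured compound 4 `CNc1ncc(-c2ccccc2)c(C(C)(C)C)n1`. In a functional assay on the whole organism for inhibition, with Rattus norvegicus as the target, with stated times of 1 h and 3.5 h, at a dose of 100 mg/kg by the oral route (a lower number here means less inhibition, a higher number more inhibition at the dose given (going by the name of the read-out)), compound 1 gives < 5%, which is a limit of the assay and not a number (the limit of < 5% in this assay, at which 1 of the 3 values shown sits). In this assay compound 2 gives 22%, and compound 3 gives 24%. Compound 3 thus holds the higher of the two numbers shown, with compound 2 close to it: a number 2 percentage points higher from compound 2 to compound 3 (within the scatter). Both acylated amino groups brought a rise over the phenyl group: a number at least 17 percentage points higher from compound 1 to compound 2 (beyond the scatter) and a number at least 19 percentage points higher from compound 1 to compound 3 (beyond the scatter).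

Compound 4 differs from compound 3 by methyl in place of ethoxycarbonyl on a nitrogen on an aromatic ring. Going by the values given here, no measured step bears directly on this change; the measured steps either replace phenyl with an acylated amino group or exchange one acyl group for another. Among the compounds with values here, the two acylated amino compounds sit near one another, while the one compound without an amino group stays at the limit. Whether a methylamino group behaves like the acylated ones is open, so the expectation is uncertain. Compound 4 is expected to give 15%, between 2% and 30%. The expected step is a number 9 percentage points lower from compound 3 to compound 4 (within the scatter), a modest fall, with a real chance that only a limit is reported.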

Compound 4, a percentage reported as inhibition, in the whole organism at one dose (the size of the read-out at that dose, not a potency): 37%
Beside the measured number, compound 4's estimate is 22 percentage points below it; measured number above the stated range.
By their numbers in this assay, from the lowest: compounds 2 and 3 (each within the scatter of the next); then compound 4. At a limit, below all of these: compound 1.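

In this assay, an acyl group on the nitrogen on the aromatic ring proves unnecessary for the read-out, as methyl in place of ethoxycarbonyl gives a number 13 percentage points higher from compound 3 to compound 4 (beyond the scatter), and methylamino in place of diacetylamino gives a number 15 percentage points higher from compound 2 to compound 4 (beyond the scatter). Compounds 2 and 3 lie within the scatter of each other, so the two acylated groups now stand together apart from methylamino, and replacing phenyl with methylamino gives a number at least 32 percentage points higher from compound 1 to compound 4 (beyond the scatter), a large step that the acylated groups did not reach. That last step starts from a limit of the assay, held by compound 1: the limit of < 5% in this assay, at which 1 of the 4 values shown sits.

Going by these compounds alone, with methylamino as the only unacylated amino group, the loss of the carbonyl cannot be separated from the drop in group size, and a single dose gives the size of the read-out and not a potency. From the compounds shown here alone, whether the rise continues with the unsubstituted amine, or gives way with dimethylamino, ethylamino or a longer chain on this nitrogen, remains open.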